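The source may hold more compounds than are shown below. What is called first, only, known or untested is meant among the compounds shown, and "the series" means these compounds.

Working notes on a dienamide series tested in an assay for inhibition of Polyunsaturated fatty acid 5-lipoxygenase (Homo sapiens), read by spectrophotometry, tested at 20 uM; on this read-out higher numbers stand for more inhibition at the one concentration tested (going by the name of the read-out) and lower numbers for less inhibition.

Compound 1 `CN(C)c1ccc(/C=C/C=C/C(=O)N2CCCCC2)cc1` gives 13.4%, the lowest of the three numbers seen so far. The nearest value belongs to compound 3 `O=C(/C=C/C=C/C=C/c1ccc(O)c(O)c1)N1CCCCC1`, which gives 30.3%, a gap beyond the usual scatter; the furthest is compound 2 `COc1cc(OC)c(/C=C/C=C/C(=O)N2CCCCC2)c(OC)c1`, which gives 77.1%, again beyond the scatter. Both of the other two compounds therefore show more inhibition than compound 1 in this assay, and the trimethoxy-substituted compound 2 stands clearly highest of the three.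

The next compound, compound 4 `O=C(/C=C/C=C/c1ccc(F)cc1)N1CCCCC1`, is reached from compound 1 by one change on the aromatic ring: fluoro in place of dimethylamino on an aromatic carbon. Among the measured compounds shown here, no step between measured compounds covers this change, so the expectation rests only on the three values in hand. For compound 4 the step of a number 6.6 percentage points higher from compound 1 to compound 4 (within the scatter) is expected to be small and is estimated to stay within the scatter of this assay, the direction being uncertain. Compound 4 is estimated at 20%, with a range from 5% to 45%.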

Compound 4, a percentage reported as inhibition, at one concentration (the size of the read-out at that concentration, not a potency): 48.7%
The estimate for compound 4 lay 28.7 percentage points below the measured number; the whole stated range lies below it.
By their numbers in this assay, from the lowest: compound 1; then compound 3; then compound 4; then compound 2.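

In this assay the aromatic carbon para to a large group proves sensitive to its substituent: fluoro in place of dimethylamino gives a number 35.3 percentage points higher from compound 1 to compound 4 (beyond the scatter), with the rest of the core of compound 1 unchanged. Among the compounds shown here, this is the first comparison that differs in one place, and it shows that this single exchange, from 3 heavy atoms to 1 heavy atom and from 1 hydrogen-bond acceptor to 0, is enough to produce a large step. Nothing on hand offers an explanation for the step.

The compounds shown cannot tell whether the step reflects the loss of dimethylamino or the gain of fluoro. Chloro, methoxy or plain hydrogen at this same position would help to separate the two, and whether the step carries over to other cores remains open.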